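Cyano in Place of Methoxy: Estimating Compound 4

The source may hold more compounds than are shown below. What is called first, only, known or untested is meant among the compounds shown, and "the series" means these compounds.

Compound 1 `COc1ccc(-n2cc(COc3c(/C=C\C(=O)O)ccc(OC)c3CC=C(C)C)nn2)cc1`: 8700 nM
Compound 2 `COc1ccc(/C=C\C(=O)O)c(OCc2cn(-c3ccc(NC(C)=O)cc3)nn2)c1CC=C(C)C`: "not determined" (no result reported)
Compound 3 `COc1cccc(-n2cc(COc3c(/C=C\C(=O)O)ccc(OC)c3CC=C(C)C)nn2)c1`: 21600 nM

Within the data shown here, in a functional assay on HCT-116 cells (Homo sapiens) for cytotoxicity, read by MTT assay, with a stated time of 24 h (a higher number here means a weaker inhibitor, a lower number a stronger inhibitor), compound 3 holds the higher of the two reported numbers; the single measured step, a 2.5-fold higher number from compound 1 to compound 3 (0.39 log units; beyond the scatter), comes from moving the methoxy group, and it separates compound 3 from compound 1 by more than the scatter. Compound 2 has no result in this assay.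

Compound 4 `COc1ccc(/C=C\C(=O)O)c(OCc2cn(-c3cccc(C#N)c3)nn2)c1CC=C(C)C` differs from compound 3 in one place: cyano in place of methoxy on an aromatic carbon. Among the measured compounds shown here, no measured step involves a cyano group entering or a methoxy leaving, so nothing in the data bears directly on this change. Compound 4 is therefore expected to stay near compound 3, with a 1.1-fold lower number from compound 3 to compound 4 (0.03 log units; within the scatter) not exceeding the scatter. The estimate for compound 4 is 20000 nM, expected to lie between 7000 nM and 60000 nM.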

Compound 4, half-maximal inhibitory concentration: 35300 nM
Compound 4: middle estimate off by 1.8-fold (0.25 log units), on the low side; measured number inside the range.
By their numbers in this assay, from the lowest: compound 1; then compounds 3 and 4 (each within the scatter of the next).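

In this assay the change of group itself, cyano in place of methoxy on this aromatic carbon, gives a 1.6-fold higher number from compound 3 to compound 4 (0.21 log units; within the scatter) and so does not separate the two compounds. Compound 1 remains apart, as a 4.1-fold higher number from compound 1 to compound 4 (0.61 log units; beyond the scatter) shows, but that step changes both the group and its place. No measured evidence accounts for either step.

From the compounds shown here alone, whether an amine or a carboxylic acid on this aromatic carbon would give a clearly different number stays open. So does the effect of 4-cyanophenyl, which would show whether cyano behaves differently at the place held by the methoxy group of compound 1.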